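The source may hold more compounds than are shown below. What is called first, only, known or untested is meant among the compounds shown, and "the series" means these compounds.

Measured in a functional assay on KB cells (Homo sapiens) for cytotoxicity; on this read-out lower numbers stand for stronger inhibition and higher numbers for weaker inhibition:
- compound 1 `COc1ccc(S(=O)(=O)N2CCc3cccc(NC(=O)c4cccs4)c32)cc1`: 47 nM
- compound 2 `COc1ccc(S(=O)(=O)N2CCc3cccc(NC(C)=O)c32)cc1`: 89 nM
- compound 3 `COc1ccc(S(=O)(=O)N2CCc3cc(Br)cc(NC(=O)c4ccco4)c32)cc1`: 89 nM

Compound 2 at 89 nM reads the same as compound 3 at 89 nM in this series. Its gap to compound 1 lies within the scatter.

The next compound is compound 4 `COc1ccc(C(=O)Nc2cccc3c2N(S(=O)(=O)c2ccc(OC)cc2)CC3)cc1`, with 4-methoxyphenyl in place of methyl on a carbonyl carbon.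

For the measured compounds named here, one measured step bears on this change: a 1.9-fold higher number from compound 1 to compound 2 (0.28 log units; within the scatter). It too exchanges methyl and a ring on that carbonyl carbon, and it stays within the scatter. Going by the values given here, compound 3 differs from compound 2 in more than one place, so it gives no clean step. Among the compounds with values here, no measured compound carries a six-membered aromatic ring on this carbonyl, so the transfer from the thiophen-2-yl case is uncertain.

In this assay, a small shift towards a lower number is expected, with no step beyond the scatter: the expected step is a 1.3-fold lower number from compound 2 to compound 4 (0.10 log units; within the scatter).

Compound 4 is estimated at 70 nM, with an expected range of 25 nM to 220 nM.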

Compound 4, half-maximal inhibitory concentration: 2600 nM
For compound 4 the middle estimate is 37-fold (1.57 log units) below the measured one; measured number outside the range, above it.
By their numbers in this assay, from the lowest: compounds 1, 2 and 3 (each within the scatter of the next); then compound 4.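

In this assay, for the compounds shown here, the carbonyl carbon on the amide-type nitrogen turns out to be far more sensitive to its substituent than the earlier compounds showed: 4-methoxyphenyl in place of methyl gives a 29-fold higher number from compound 2 to compound 4 (1.47 log units; beyond the scatter) and 4-methoxyphenyl in place of thiophen-2-yl gives a 55-fold higher number from compound 1 to compound 4 (1.74 log units; beyond the scatter) with both steps large. A ring on this carbonyl therefore does not by itself hold the number down, as thiophen-2-yl in compound 1 stays within the scatter of methyl in compound 2 while 4-methoxyphenyl in compound 4 does not. No measurement at hand accounts for this loss.

The compounds shown do not separate the six-membered aromatic ring from its methoxy group, so a plain phenyl on this carbonyl would be informative. Also open, from the compounds shown here alone, is how a longer alkyl chain or an amine would read at this place.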